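This account rests on a few compounds, and the source may have more. Where it says the series, first, only, none or still open, it means among the compounds named here.

Measured compounds:
Compound 1 `CNC(=O)c1ccccc1Oc1nc(Nc2ccc(C(F)(F)F)cc2)ncc1Br` — in a functional assay on MCF7 cells (Homo sapiens) for antiproliferative activity, read by MTT assay, with a stated time of 24 h (on this read-out lower numbers stand for stronger inhibition and higher numbers for weaker inhibition), compound 1 gives > 50000 nM, a limit of the assay.
Compound 2 `CNC(=O)c1ccccc1Oc1nc(Nc2ccccc2F)ncc1Br` — in this assay compound 2 gives > 50000 nM, also a limit of the assay.

Compound 2 therefore stands at the limit, not at a number; the same holds for the other value shown, as the limit of > 50000 nM in this assay, at which 2 of the 2 values shown sit, records. Compound 3 `CNC(=O)c1ccccc1Oc1nc(Nc2ccccc2OC)ncc1Br` is not yet measured. The change from compound 2 is methoxy in place of fluoro on an aromatic carbon. Within the data shown here, no step between measured compounds is available, so the direction of a step that the limit leaves unreadable from compound 2 to compound 3 is expected to be flat, with no step beyond the scatter. Compound 3 is estimated at 60000 nM (range 20000 nM to 200000 nM).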

Compound 3, half-maximal inhibitory concentration: > 50000 nM
Compound 3 gave a limit, no number (the forecaster's own chance of this, stated with the estimate: 80%); the middle value does not contradict the limit.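

No step can be read from compound 2 to compound 3, as both values are limits, not numbers: the limit of > 50000 nM in this assay, at which 3 of the 3 values shown sit.

The compounds shown leave open what methoxy in place of fluoro changes, and whether any compound in the series gives a number rather than a limit.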